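Replacing the chloro with a methionine-derived amino group

A few compounds are considered here, and "the series" means these few. Any claim that something is new, unique, unknown or untested is made for them only; others in the source may bear on it.

Compound 1 `COc1cc(-c2nc3ccccc3s2)ccc1OCC(=O)NNC(=O)CCl` is the starting point of this series. In a functional assay on HepG2 cells (Homo sapiens) for inhibition, read by MTT assay, with a stated time of 3 days (on this read-out higher numbers stand for weaker inhibition and lower numbers for stronger inhibition), compound 1 gives 2890 nM, the lowest of the three numbers, though its distances to compound 2 and compound 3 both lie within the scatter. Compound 2 `COc1cc(-c2nc3ccccc3s2)ccc1OCC(=O)NNC(=O)CN[C@@H](CS)C(=O)O` gives 3120 nM, and compound 3 `CCOC(=O)[C@H](CS(=O)(=O)O)NCC(=O)NNC(=O)COc1ccc(-c2nc3ccccc3s2)cc1OC` gives 3360 nM. The two measured changes at the chloro position, a 1.1-fold higher number from compound 1 to compound 2 (0.03 log units; within the scatter) and a 1.2-fold higher number from compound 1 to compound 3 (0.07 log units; within the scatter), stayed within the scatter, as did a 1.1-fold higher number from compound 2 to compound 3 (0.03 log units; within the scatter), which exchanged one amino acid side chain for another.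

Compound 4 `CCOC(=O)[C@H](CCSC)NCC(=O)NNC(=O)COc1ccc(-c2nc3ccccc3s2)cc1OC` carries a related change: (1-(ethoxycarbonyl)-3-(methylsulfanyl)propyl)amino in place of chloro on a saturated chain carbon bound to a carbonyl carbon. Both measured replacements of the chloro by an amino acid derivative left the read-out essentially unchanged, so no step beyond the scatter is expected here either. Compound 4 is therefore estimated at 3300 nM, within the range 1700 nM to 6500 nM, corresponding to an expected 1.1-fold higher number from compound 1 to compound 4 (0.06 log units; within the scatter).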

Compound 4, half-maximal inhibitory concentration: 3330 nM
The estimate for compound 4 lay 1.0-fold (0.00 log units) below the measured number; the range from low to high includes it.
By their numbers in this assay, from the lowest: compounds 1, 2, 4 and 3 (each within the scatter of the next).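

In this assay, the (1-(ethoxycarbonyl)-3-(methylsulfanyl)propyl)amino group, with 11 heavy atoms where chloro had one, stayed within the scatter (a 1.2-fold higher number from compound 1 to compound 4 (0.06 log units; within the scatter)), so a third amino acid-derived group on the saturated chain carbon bound to a carbonyl carbon left the number in place. The comparisons among these groups also stayed within the scatter, both for (methylsulfanyl)methyl in place of sulfo (a 1.0-fold lower number from compound 3 to compound 4 (0.00 log units; within the scatter)) and for the exchange of the whole amine substituent (a 1.1-fold higher number from compound 2 to compound 4 (0.03 log units; within the scatter)), so this read-out separates none of the four compounds. The data offer no explanation for this flat result.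

The compounds shown leave open whether a morpholine or a dimethylamino group in place of chloro would also stay within the scatter. They also leave open whether replacing the methoxy group on the shared core would change the number.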